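Swapping piperidine for methylpiperazine on the chain tail

The compounds below may be only part of what the source reports. "The series", "measured", "known", "first", "only" and "open" are said of these compounds alone.

Compound 3 `COc1cc2c(Oc3ccc(NC(=O)c4nn(-c5ccccc5C)c(=O)cc4C)cc3F)ccnc2cc1OCCCN1CCCCC1` gives 2500 nM in a functional assay on U-87MG ATCC cells (Homo sapiens) for inhibition, read by MTT assay, with a stated time of 72 h (a higher number here means a weaker inhibitor, a lower number a stronger inhibitor), the second highest of the three numbers measured. Compound 1 `COc1cc2c(Oc3ccc(NC(=O)c4nn(-c5ccccc5)c(=O)cc4C)cc3F)ccnc2cc1OCCCN1CCN(C)CC1` gives 2120 nM and compound 2 `COc1cc2c(Oc3ccc(NC(=O)c4nn(-c5ccccc5C)c(=O)cc4C)cc3F)ccnc2cc1OCCCN1CCCC1` gives 2960 nM, and both sit within the scatter of compound 3. Within the data shown here, the one measured step touching this part of the molecule, a 1.2-fold lower number from compound 2 to compound 3 (0.07 log units; within the scatter), was within the scatter. Compound 4 `COc1cc2c(Oc3ccc(NC(=O)c4nn(-c5ccccc5C)c(=O)cc4C)cc3F)ccnc2cc1OCCCN1CCN(C)CC1` differs from compound 3 by 4-methylpiperazin-1-yl in place of piperidin-1-yl on a saturated chain carbon, three bonds along the chain from an oxygen on an aromatic ring. Compound 1 already carries the 4-methylpiperazin-1-yl group at this place, on a different aryl partner, and its value lies within the scatter of compound 3. The expected step is therefore a 1.1-fold lower number from compound 3 to compound 4 (0.04 log units; within the scatter), nothing beyond the scatter. Compound 4 is estimated at 2300 nM, with a range from 1200 nM to 4500 nM.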

Compound 4, half-maximal inhibitory concentration: 3720 nM
The estimate for compound 4 lay 1.6-fold (0.21 log units) below the measured number; low and high end bracket the measured number.
By their numbers in this assay, from the lowest: compounds 1, 3, 2 and 4 (each within the scatter of the next).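

In this assay, with the same methylphenyl partner on the shared core, a 1.5-fold higher number from compound 3 to compound 4 (0.17 log units; within the scatter) and a 1.3-fold higher number from compound 2 to compound 4 (0.10 log units; within the scatter) show that the 4-methylpiperazin-1-yl tail cannot be told apart from the piperidin-1-yl or pyrrolidin-1-yl tails. Methyl in place of hydrogen on an aromatic carbon, read with this tail, gives a 1.8-fold higher number from compound 1 to compound 4 (0.24 log units; within the scatter) and is also not a readable change. No measurement at hand bears on these steps.

From the compounds shown here alone, whether a morpholin-4-yl or dimethylamino tail, or a shorter chain, would move the number beyond the scatter remains open.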